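Removing the Methyl From Compound 1: An Expected Step

The source may hold more compounds than are shown below. What is called first, only, known or untested is meant among the compounds shown, and "the series" means these compounds.

Compound 1 `Cc1ccnc(/C(N)=N/NC(=S)N2CCCCCC2)c1` carries a methyl group on a six-membered aromatic ring with one nitrogen, joined through an amidine-type linker to a thiourea on a seven-membered saturated ring. Among the compounds with values here, in a functional assay on MCF7 cells (Homo sapiens) for cytotoxicity, read by MTT assay, with a stated time of 72 h, tested at 10 uM (on this read-out lower numbers stand for less inhibition of growth and higher numbers for more inhibition of growth at the one concentration tested), compound 1 gives 60.3%, the higher of the two numbers measured so far. Compound 2 `Cc1cccc(/C(N)=N/NC(=S)N2CCCC2)n1`, which bears the methyl at a different place and a five-membered saturated ring instead, gives 38.2% in this assay, a lower figure by more than the usual scatter; since two parts differ, the two values alone cannot be pulled apart.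

Compound 3 `N/C(=N\NC(=S)N1CCCCCC1)c1ccccn1` is compound 1 with hydrogen in place of methyl on an aromatic carbon. Only one heavy atom leaves and nothing new is added. Such a small removal is expected to cost a little growth inhibition, so the step of a number 10.3 percentage points lower from compound 1 to compound 3 (beyond the scatter) is estimated as modest. Compound 3 is therefore expected to give about 50% in this assay, with a likely span from 30% to 68%.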

Compound 3, percent growth inhibition at one concentration: 62.2%
Beside the measured number, compound 3's estimate is 12.2 percentage points below it, within the range that was stated.
By their numbers in this assay, from the lowest: compound 2; then compounds 1 and 3 (each within the scatter of the next).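

In this assay, within the data shown here, putting hydrogen in place of methyl on an aromatic carbon gives a number 1.9 percentage points higher from compound 1 to compound 3 (within the scatter), the first comparison here in which only one place differs. At this position, opposite the ring nitrogen, the methyl can therefore be removed with no change beyond the scatter, so this pair gives no sign that the methyl is needed for growth inhibition at the one concentration tested. Nothing available explains this result or indicates how the shared core responds to this change.

Going by these compounds, it remains open whether a larger or different group on this same aromatic carbon, such as an amine, a carboxylic acid or a longer chain, would also leave the number within the scatter. Also open is what the seven-membered saturated ring contributes on its own, as no pair shown differs in that ring alone.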